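A few compounds are considered here, and "the series" means these few. Any claim that something is new, unique, unknown or untested is made for them only; others in the source may bear on it.

Going by the values given here, compound 2, with the structure `COc1cc(C=C2C(=O)N(c3ccc(Cl)cc3)N(c3ccc(Cl)cc3)C2=O)ccc1O`, is one of two compounds measured in a functional assay on ECa-109 cells (Homo sapiens) for cytotoxicity, read by MTT assay, with a stated time of 72 h; a lower number here means a stronger inhibitor, a higher number a weaker inhibitor. Compound 2 gives 7100 nM in this assay. Among the compounds with values here, its only neighbour is compound 1, with the structure `O=C1C(=Cc2ccc(Br)cc2)C(=O)N(c2ccc(Cl)cc2)N1c1ccc(Cl)cc1`, and in this assay compound 1 gives 12300 nM. The step of a 1.7-fold lower number from compound 1 to compound 2 (0.24 log units; within the scatter) is within the scatter, so compound 2 stands level with compound 1 and neither can be called the stronger inhibitor.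

Compound 3, with the structure `COc1cccc(C=C2C(=O)N(c3ccc(Cl)cc3)N(c3ccc(Cl)cc3)C2=O)c1O`, differs from compound 2 in one place: 2-hydroxy-3-methoxyphenyl in place of 4-hydroxy-3-methoxyphenyl on a double-bonded chain carbon bound to a double-bonded ring carbon. The two groups have the same atoms, only joined differently.

Within the data shown here, the one measured step, from compound 1 to compound 2, exchanged the whole ring substituent at this same place and still moved the number only a 1.7-fold lower number from compound 1 to compound 2 (0.24 log units; within the scatter), within the scatter. Among the measured compounds shown here, no measured step mirrors the shift of the hydroxy group itself. With so little to go on, the expectation is that the step of a 1.1-fold higher number from compound 2 to compound 3 (0.05 log units; within the scatter) will stay within the scatter, in no particular direction. Compound 3 is therefore estimated at 8000 nM in this assay, with a range from 3000 nM to 22000 nM.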

Compound 3, half-maximal inhibitory concentration: 39000 nM
Compound 3: middle estimate off by 4.9-fold (0.69 log units), on the low side; measured number outside the range, above it.
By their numbers in this assay, from the lowest: compounds 2 and 1 (each within the scatter of the next); then compound 3.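

In this assay, moving the hydroxy group around the ring, with no atom gained or lost, gives a 5.5-fold higher number from compound 2 to compound 3 (0.74 log units; beyond the scatter). Going by these compounds alone, this is the first step beyond the scatter at this place on a double-bonded chain carbon bound to a double-bonded ring carbon, since the exchange of the whole ring substituent gave only a 1.7-fold lower number from compound 1 to compound 2 (0.24 log units; within the scatter). The 2-hydroxy-3-methoxyphenyl group also separates from the 4-bromophenyl group, with a 3.2-fold higher number from compound 1 to compound 3 (0.50 log units; beyond the scatter), so in these three compounds the way the same atoms are joined counts for more than the earlier swap of one substituted ring for another. No measurement at hand gives a reason for this shift.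

Whether the higher number of compound 3 depends on the hydroxy group alone or on the hydroxy and methoxy groups together stays open, as the compounds shown offer no ring carrying only one of the two. From the compounds shown here alone, how an amine or a carboxylic acid on the ring would behave at this same place also remains unknown, and three compounds are too few to support a general rule.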